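The compounds below may be only part of what the source reports. "The series", "measured", "known", "first", "only" and "open" are said of these compounds alone.

Measured so far in this study:
compound 1, `c1ccc(CNCC2CCN(CCCc3c[nH]c4ccc(-n5cnnc5)cc34)CC2)cc1`: 5.6 nM
compound 2, `COC[C@H](NC1CCN(CCCc2c[nH]c3ccc(-n4cnnc4)cc23)CC1)c1ccccc1`: 0.9 nM
compound 3, `c1ccc2c(c1)CCC2NCC1CCN(CCCc2c[nH]c3ccc(-n4cnnc4)cc23)CC1`: 1.3 nM

In an assay on CHO cells for agonist activity at 5-hydroxytryptamine receptor 1D (Homo sapiens), read by GTPgammaS binding (on this read-out higher numbers stand for an effect only at larger amounts of compound and lower numbers for an effect already at smaller amounts), compound 3 gives 1.3 nM. The step of a 1.4-fold higher number from compound 2 to compound 3 (0.16 log units; within the scatter) lies within the scatter, whereas the step of a 4.3-fold lower number from compound 1 to compound 3 (0.63 log units; beyond the scatter) lies beyond it. Compound 4 `CC(CO)(NC1CCN(CCCc2c[nH]c3ccc(-n4cnnc4)cc23)CC1)c1ccccc1` alters the group on the saturated ring: (1-(hydroxymethyl)-1-phenylethyl)amino in place of ((2,3-dihydro-1H-inden-1-yl)amino)methyl on a saturated ring carbon. Within the data shown here, two measured steps bear on this. a 6.2-fold lower number from compound 1 to compound 2 (0.79 log units; beyond the scatter) shows that an amine set directly on the ring carbon, bearing a phenyl and an oxygen-containing side chain, gives lower numbers than the benzylamino-methyl arrangement, while a 1.4-fold higher number from compound 2 to compound 3 (0.16 log units; within the scatter) shows the arrangements of compounds 2 and 3 about on a par. Compound 4 keeps the direct-amine arrangement of compound 2, with a hydroxymethyl and a methyl in place of the methoxymethyl. The expected step, a 1.2-fold higher number from compound 3 to compound 4 (0.06 log units; within the scatter), is therefore small and not beyond the scatter. Compound 4 is estimated at 1.5 nM, within 0.5 nM to 5 nM.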

Compound 4, half-maximal effective concentration: 3.4 nM
For compound 4 the middle estimate is 2.3-fold (0.36 log units) below the measured one, and the stated range covers the measured number.
By their numbers in this assay, from the lowest: compounds 2 and 3 (each within the scatter of the next); then compounds 4 and 1 (each within the scatter of the next).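

Directly on the saturated ring carbon, the amine does not keep the number low whatever it carries: 1-(hydroxymethyl)-1-phenylethyl in place of 2-methoxy-1-phenylethyl on the amine nitrogen gives a 3.8-fold higher number from compound 2 to compound 4 (0.58 log units; beyond the scatter). The group on that nitrogen therefore matters too. The new group also gives a 2.6-fold higher number from compound 3 to compound 4 (0.42 log units; beyond the scatter), yet a 1.6-fold lower number from compound 1 to compound 4 (0.22 log units; within the scatter) leaves it on a par with the (benzylamino)methyl group.

Nothing available explains these steps. On these data alone, whether the added methyl or the swap of methoxy for hydroxyl drives the rise stays open, as does the effect of a carboxylic acid in place of the hydroxymethyl.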